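Phenyl substituent changes in a fused bicyclic series

This account rests on a few compounds, and the source may have more. Where it says the series, first, only, none or still open, it means among the compounds named here.

Measured compounds and values in a functional assay on SK-MEL-2 cells (Homo sapiens) for inhibition, read by sulforhodamine B assay, with a stated time of 48 h, tested at 10 uM; a lower number here means less inhibition, a higher number more inhibition at the concentration tested (going by the name of the read-out):
compound 1, `c1ccc(-c2cn3ccnc3c(-c3ccc4ncn(C5CCCCC5)c4c3)n2)cc1`: 16.5%
compound 2, `CC(=O)c1ccc(-c2cn3ccnc3c(-c3ccc4ncn(C5CCCCC5)c4c3)n2)cc1`: 0.58%
compound 3, `Brc1ccc(-c2cn3ccnc3c(-c3ccc4ncn(C5CCCCC5)c4c3)n2)cc1`: 24.1%

Compound 3 holds the highest of the three numbers in this assay. The nearest is compound 1, whose number lies within the scatter of it a number 7.6 percentage points higher from compound 1 to compound 3 (within the scatter); the furthest is compound 2, separated by a step beyond the scatter a number 23.5 percentage points higher from compound 2 to compound 3 (beyond the scatter). Going by the values given here, the only step that is clearly beyond the scatter in this set is the one that puts acetyl in place of hydrogen on the aromatic carbon a number 15.9 percentage points lower from compound 1 to compound 2 (beyond the scatter).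

Compound 4, `COc1ccccc1-c1cn2ccnc2c(-c2ccc3ncn(C4CCCCC4)c3c2)n1`, differs from compound 3 in one place: 2-methoxyphenyl in place of 4-bromophenyl on an aromatic carbon. Among the compounds with values here, no measured step moves a group to that part of the ring, and no measured compound carries methoxy anywhere, so the step has no direct precedent here. The measured steps show that hydrogen and bromo sit within the scatter of each other, while acetyl sits well below both. An oxygen-bearing group is closer in kind to acetyl than to bromo, so the expected step is a number 12.1 percentage points lower from compound 3 to compound 4 (beyond the scatter), a drop of modest size. Compound 4 is therefore estimated at 12%, with a range from 0% to 28%.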

Compound 4, a percentage reported as inhibition, at one concentration (the size of the read-out at that concentration, not a potency): 12.1%
Compound 4: middle estimate off by 0.1 percentage points, on the low side; the range from low to high includes it.
By their numbers in this assay, from the lowest: compound 2; then compounds 4, 1 and 3 (each within the scatter of the next, the first and the last beyond it).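

Going by these compounds alone, the series in this assay now holds a second oxygen-bearing group, and it does not follow acetyl: there is a number 11.5 percentage points higher from compound 2 to compound 4 (beyond the scatter) on exchanging 4-acetylphenyl for 2-methoxyphenyl, and a number 4.4 percentage points lower from compound 1 to compound 4 (within the scatter) against the unsubstituted phenyl, so compound 2 remains the only compound set apart at the low end. Within the data shown here, there is also a number 12 percentage points lower from compound 3 to compound 4 (beyond the scatter) on exchanging 4-bromophenyl for 2-methoxyphenyl, the first step beyond the scatter in this set that involves neither acetyl nor compound 2, although it alters both the substituent and its place on the phenyl ring and cannot be assigned to either change alone. Nothing available explains these differences in the numbers.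

Going by these compounds, whether methoxy would read the same at the place held by bromo and acetyl remains open, as does whether bromo or acetyl would keep their readings at the place held by methoxy. On these data alone, it is also open how an amine or a carboxylic acid on the phenyl ring would compare, and whether any such group would stand apart from compound 1 and compound 3 or sit low with compound 2.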